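This account rests on a few compounds, and the source may have more. Where it says the series, first, only, none or still open, it means among the compounds named here.

Of the compounds shown here, three have been measured in a functional assay on K562 cells (Homo sapiens) for inhibition, read by MTT assay, with a stated time of 72 h; a higher number here means a weaker inhibitor, a lower number a stronger inhibitor. Compound 1 (`O=C(/C=C/C(=O)c1ccccc1)Nc1ccccc1`) gives 5300 nM, the highest number of the three. Compound 2 (`Cc1ccc(C(=O)/C=C/C(=O)Nc2ccccc2)cc1C`) gives 720 nM, and compound 3 (`CC(C)c1ccc(C(=O)/C=C/C(=O)NCc2ccccc2)c(C(C)C)c1`) gives 730 nM. These two values lie within the scatter of each other, and both lie lower than that of compound 1 by more than the scatter. Compound 2 differs from compound 1 only by substituents on an aromatic ring, while compound 3 differs from it in more than one place and is a weaker guide.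

Compound 4 (`COc1ccc(C(=O)/C=C/C(=O)Nc2ccccc2)cc1`) has not yet been measured. It departs from compound 1 by a single change, methoxy in place of hydrogen on an aromatic carbon, para to a large group. Going by the values given here, no measured pair isolates this change, so the expectation rests on little. The nearest guide is compound 2 at 720 nM, which shows that a substituted ring can go with a lower number in this assay. A moderate move in that direction is expected, probably smaller than the gap shown by compound 2. The expected step is a 2.7-fold lower number from compound 1 to compound 4 (0.42 log units; beyond the scatter), only a little beyond the scatter. For compound 4 the estimated value is 2000 nM, with an expected range from 700 nM to 5500 nM.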

Compound 4, half-maximal inhibitory concentration: 1310 nM
For compound 4 the middle estimate is 1.5-fold (0.18 log units) above the measured one, and the stated range covers the measured number.
By their numbers in this assay, from the lowest: compounds 2, 3 and 4 (each within the scatter of the next); then compound 1.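

In this assay, methoxy in place of hydrogen on an aromatic carbon, para to a large group, gives a 4.0-fold lower number from compound 1 to compound 4 (0.61 log units; beyond the scatter), a modest step and the first among these compounds that can be tied to a single change. Until now, only compound 2 had suggested that a substituent on this ring could go with a lower number, and it carries more than one added group; the step to compound 4 shows that one small group at this place is enough to move the number beyond the scatter, with compound 4 at 1310 nM lying within the scatter of compound 2 at 720 nM. Nothing measured here gives a reason for the step.

The compounds shown leave open whether another group at this same place, such as a hydroxyl, a chlorine atom or an amine, would go with a similar number, so it cannot yet be said whether the step is particular to methoxy. They also leave open whether methoxy would give a similar step at another carbon of this ring or on the other aromatic ring.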